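A few compounds are considered here, and "the series" means these few. Any claim that something is new, unique, unknown or untested is made for them only; others in the source may bear on it.

Compound 1, `CN(C)c1ccc(C2CC(c3ccc(-n4cncn4)cc3)=NN2)cc1`, gives 6.8% in a functional assay on HCC1806 cells (Homo sapiens) for inhibition, read by sulforhodamine B assay, tested at 10 uM; a higher number here means more inhibition at the concentration tested (going by the name of the read-out), a lower number less inhibition.
Compound 2, `CN(C)c1ccc(C2CC(c3ccc(-n4cncn4)cc3)=NN2C(=O)c2ccc(C(F)(F)F)cc2)cc1`, gives 7% in this assay.

Both numbers are small, meaning neither compound blocks much of the cell growth at the concentration tested. Within the data shown here, compound 2 holds the highest of the two numbers, but its only neighbour, compound 1, lies just a number 0.2 percentage points higher from compound 1 to compound 2 (within the scatter), a gap within the scatter, so the two cannot be told apart.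

Compound 3, `CN(C)c1ccc(C2CC(c3ccc(-n4cncn4)cc3)=NN2S(=O)(=O)c2ccc(F)cc2)cc1`, is built on the same core and differs from compound 2 in one place: (4-fluorophenyl)sulfonyl in place of (4-(trifluoromethyl)phenyl)carbonyl on an amine nitrogen in a ring.

Among the measured compounds shown here, the one measured step that touches this ring nitrogen is the one from compound 1 to compound 2, where a hydrogen was replaced by a (4-(trifluoromethyl)phenyl)carbonyl; it measured a number 0.2 percentage points higher from compound 1 to compound 2 (within the scatter), within the scatter. For the measured compounds named here, no measured step exchanges one group for another on that nitrogen, so the present change is untested. Given that adding a group there changed nothing, compound 3 is expected to stay near compound 2, with a step of about a number 1 percentage points higher from compound 2 to compound 3 (within the scatter). The estimate for compound 3 in this assay is 8%, within a range of -5% to 25%.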

Compound 3, a percentage reported as inhibition, at one concentration (the size of the read-out at that concentration, not a potency): 24.1%
Compound 3: the middle estimate sits 16.1 percentage points below what was measured; the range from low to high includes it.
By their numbers in this assay, from the lowest: compounds 1 and 2 (each within the scatter of the next); then compound 3.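

The ring nitrogen of the shared core is not a silent position in this assay: the earlier pair suggested that a group placed there changes nothing, yet (4-fluorophenyl)sulfonyl in place of (4-(trifluoromethyl)phenyl)carbonyl gives a number 17.1 percentage points higher from compound 2 to compound 3 (beyond the scatter) and the same group in place of hydrogen gives a number 17.3 percentage points higher from compound 1 to compound 3 (beyond the scatter). What matters at this nitrogen is therefore which group sits there, and not merely whether the hydrogen has been replaced, since the carbonyl group left the reading within the scatter of the hydrogen while the sulfonyl group did not. Still, the step remains modest, and nothing available here accounts for it.

This change swaps the carbonyl for a sulfonyl and the trifluoromethyl for a fluorine at the same time, so the compounds shown cannot say which of the two carries the step; (4-(trifluoromethyl)phenyl)sulfonyl or (4-fluorophenyl)carbonyl on this nitrogen would separate them. Also open, going by these compounds, is whether the aromatic ring on the sulfonyl is needed at all, a question that a small methylsulfonyl group at the same place would address.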